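The compounds below may be only part of what the source reports. "The series", "measured", "known", "first", "only" and "open" are said of these compounds alone.

The measured compounds:

Compound 1, `C#CC(C)OC(=O)c1ccc(C(CC)(CC)c2ccc(OCCC(O)(CC)CC)c(C)c2)n1CC`: > 50000 nM
Compound 2, `CCC(C)C(NC(=O)c1ccc(C(CC)(CC)c2ccc(OCCC(O)(CC)CC)c(C)c2)n1CC)C(=O)O`: 9990 nM

Both were tested in an ADME assay on L02 cells (Homo sapiens) for antiproliferative activity, read by MTT assay, with a stated time of 48 h; on this read-out higher numbers stand for weaker inhibition and lower numbers for stronger inhibition. For compound 1 the result is only a limit of the assay, not a number: compound 1 gives > 50000 nM. Going by the values given here, compound 2 gives 9990 nM in this assay, the only actual number among the two values. The other value, that of compound 1, is a limit of the assay: the limit of > 50000 nM in this assay, at which 1 of the 2 values shown sits.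

The step of interest leads from compound 2 to compound 3, `CCn1c(C(=O)NC(CO)CCO)ccc1C(CC)(CC)c1ccc(OCCC(O)(CC)CC)c(C)c1`, and changes the group on the amide-type nitrogen: 3-hydroxy-1-(hydroxymethyl)propyl in place of 1-carboxy-2-methylbutyl on an amide-type nitrogen.

Among the compounds with values here, only one measured step exists, an at least 5.0-fold lower number from compound 1 to compound 2 (0.69 log units; beyond the scatter), and it changed the group on the carbonyl carbon rather than on the amide-type nitrogen, so it bears on the new step only loosely; it does show that swapping the group at this end of the molecule can move the result across the limit. Within the data shown here, no measured step exchanges one amide substituent for another. The expected outcome is therefore a step of no clear direction, with wide uncertainty, and a fair chance that compound 3 again returns only a limit. Compound 3 is estimated at 15000 nM, within 4000 nM to 50000 nM, which means an expected step of a 1.5-fold higher number from compound 2 to compound 3 (0.18 log units; within the scatter).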

Compound 3, half-maximal inhibitory concentration: 3040 nM
For compound 3 the middle estimate is 4.9-fold (0.69 log units) above the measured one; the measured number lies below the stated range.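

In this assay, putting 3-hydroxy-1-(hydroxymethyl)propyl in place of 1-carboxy-2-methylbutyl on the amide-type nitrogen gives a 3.3-fold lower number from compound 2 to compound 3 (0.52 log units; beyond the scatter), the first measured sign that the group on this nitrogen matters, and not only the swap on the carbonyl carbon seen earlier. The entering group has 6 heavy atoms against 8 in the group that leaves, and it carries 2 hydrogen-bond donors against 1, so a smaller group with more donors is tolerated here and goes with stronger inhibition in this pair. Measured against compound 1, whose value is only a limit of the assay, the whole change on the carbonyl carbon gives an at least 16-fold lower number from compound 1 to compound 3 (1.21 log units; beyond the scatter), which makes compound 3 the strongest inhibitor of the three in this read-out.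

No measurement shown explains why the step goes this way. With one exchange on this nitrogen, the compounds leave open whether the result follows the loss of the carboxylic acid, the size of the group or its two hydroxyl groups, and a 2-hydroxyethyl chain or an amine on the same nitrogen would be needed to tell these apart.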